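A fluoro substituent on the phenyl ring of compound 3

The source may report more compounds than this note shows. Statements on the series, on what has been measured and on what is new or still open speak of the compounds shown alone.

Compound 1, `CCCOc1ccc2c(c1)C(=O)NCCO2`: compound 1 gives 78.3 mg/kg in a functional assay on the whole organism with Mus musculus as the target, in the maximal electroshock model, with stated times of 30 min and 4 h; on this read-out lower numbers stand for an effect already at smaller amounts and higher numbers for an effect only at larger amounts of compound
Compound 2, `CCCCCOc1ccc2c(c1)C(=O)NCCO2`: compound 2 gives 56.8 mg/kg in this assay
Compound 3, `O=C1NCCOc2ccc(OCc3ccccc3)cc21`: compound 3 gives 73.1 mg/kg in this assay

Among these three numbers compound 3 holds the second highest. Its nearest neighbour is compound 1, and the step of a 1.1-fold lower number from compound 1 to compound 3 (0.03 log units; within the scatter) lies within the scatter; the step of a 1.3-fold higher number from compound 2 to compound 3 (0.11 log units; within the scatter) is within the scatter as well, so the three measured compounds cannot be told apart on this read-out.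

Compound 4, `O=C1NCCOc2ccc(OCc3ccccc3F)cc21`, differs from compound 3 by fluoro in place of hydrogen on an aromatic carbon. Within the data shown here, no measured step touches a substituent on the phenyl ring: the step of a 1.4-fold lower number from compound 1 to compound 2 (0.14 log units; within the scatter) lengthens a chain, and the steps of a 1.1-fold lower number from compound 1 to compound 3 (0.03 log units; within the scatter) and a 1.3-fold higher number from compound 2 to compound 3 (0.11 log units; within the scatter) exchange a chain for phenyl, all of them within the scatter. Among the measured compounds shown here, nothing among the measured compounds therefore points to a change in either direction, and the step of a 1.0-fold lower number from compound 3 to compound 4 (0.02 log units; within the scatter) is expected to stay within the scatter. Compound 4 is accordingly estimated at 70 mg/kg, with a range from 35 mg/kg to 140 mg/kg in this assay.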

Compound 4, dose for half-maximal effect: 45.6 mg/kg
Beside the measured number, compound 4's estimate is 1.5-fold (0.19 log units) above it; the measured number falls inside the stated range.
By their numbers in this assay, from the lowest: compounds 4, 2, 3 and 1 (each within the scatter of the next).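

Fluoro, on an aromatic carbon ortho to a large group, gives the first measured change on the phenyl ring itself in this assay (a 1.6-fold lower number from compound 3 to compound 4 (0.20 log units; within the scatter)), so this position takes the added atom without a step beyond the scatter. The 2-fluorophenyl group likewise stays within the scatter of the two chains it can be set against (a 1.2-fold lower number from compound 2 to compound 4 (0.10 log units; within the scatter); a 1.7-fold lower number from compound 1 to compound 4 (0.23 log units; within the scatter)), which means that compound 4 joins compounds 1, 2 and 3 in a set that this read-out cannot separate. No available information bears on this result.

The compounds shown leave open whether a larger group on the same carbon, such as chloro, methoxy or trifluoromethyl, would produce a step beyond the scatter, and whether fluoro on another carbon of the phenyl ring would read the same. They also leave open whether an amine or a carboxylic acid on the phenyl ring, or a methyl group in place of the amide hydrogen of the shared core, would separate any compound from this set.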